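The source may hold more compounds than are shown below. What is called first, only, known or untested is meant among the compounds shown, and "the series" means these compounds.

Compound 1 `O=C(CCCCC1CCSS1)NCc1cn(CCCCOc2ccc3cc(-c4ccccc4)c(=O)oc3c2)nn1` is one of three compounds tested in a functional assay on PC-12 cells (Rattus norvegicus) for cytotoxicity, read by MTT assay, with stated times of 3 h and 2 h, tested at 20 uM (a lower number here means a weaker effect, a higher number a stronger effect of the compound at the concentration tested), where compound 1 gives 26%. Compound 2 `COc1ccc(-c2cc3ccc(OCCCCn4cc(CNC(=O)CCCCC5CCSS5)nn4)cc3oc2=O)cc1` differs from it in a single place, (methoxy in place of hydrogen on an aromatic carbon), and in this assay compound 2 gives 52.3%. That one change made a step of a number 26.3 percentage points higher from compound 1 to compound 2 (beyond the scatter). Compound 3 `O=C(CCCCC1CCSS1)NCc1cn(CCCCCOc2ccc3cc(-c4ccccc4)c(=O)oc3c2)nn1` has a different core; how the core of compound 3 differs from the core of compound 1 is not broken down here. In this assay compound 3 gives 20.7%, a number within the usual scatter of that of compound 1. Compound 4 `COc1ccc(-c2cc3ccc(OCCCCCn4cc(CNC(=O)CCCCC5CCSS5)nn4)cc3oc2=O)cc1` has not yet been measured. It differs from compound 3 by methoxy in place of hydrogen on an aromatic carbon, the same change that turned compound 1 into compound 2, at the same place on the ring. Since that change gave the step of a number 26.3 percentage points higher from compound 1 to compound 2 (beyond the scatter), a rise of similar size is expected here. On that basis the step expected is a number 24.3 percentage points higher from compound 3 to compound 4 (beyond the scatter). Compound 4 is therefore expected to give about 45%, most likely between 28% and 60%, a single earlier example being a thin base for the expectation.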

Compound 4, a percentage reported as activity, at one concentration (the size of the read-out at that concentration, not a potency): 49%
Estimate against measurement, compound 4: 4 percentage points below; the range from low to high includes it.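

In this assay, swapping phenyl for 4-methoxyphenyl on the second core gave a number 28.3 percentage points higher from compound 3 to compound 4 (beyond the scatter), and this step can be set directly beside the earlier one: the same change on two cores in this assay, a number 26.3 percentage points higher (beyond the scatter) from compound 1 to compound 2 and a number 28.3 percentage points higher (beyond the scatter) from compound 3 to compound 4, 2 percentage points apart, within the scatter of two such steps. Within these two pairs, then, the change carried over from the core of compound 1 to the core of compound 3 with its size intact, so the step on one core would have been a fair guide to the step on the other. This does not show that the step would hold on any other core in the series, nor does it explain why the number rises, and since the read-out is taken at a single concentration, it says nothing about potency.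

From the compounds shown here alone, it remains open whether another group at the same place on the ring, such as a hydroxyl, an amine or a carboxylic acid, would give a similar step. Going by these compounds alone, it also remains open whether the methoxy step would persist with a longer chain than the one in compound 3 and compound 4.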